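This account rests on a few compounds, and the source may have more. Where it says the series, first, only, none or still open, it means among the compounds named here.

Measured so far in a functional assay on HEK-293T cells (Homo sapiens) for cytotoxicity, read by MTT assay; a higher number here means that more compound is tolerated, a lower number that less compound is tolerated:
compound 1 `COc1ccc(-c2nc3ccccn3c2Nc2cc(OC)c(OC)c(OC)c2)cc1O` gives 10000 nM
compound 2 `COc1ccc(Nc2c(-c3ccc(F)cc3)nc3cnccn23)cc1` gives 56000 nM

In this assay compound 2 stands higher of the two at 56000 nM and compound 1 lies lower at 10000 nM by a gap beyond the usual scatter. Next comes compound 3 `COc1ccc(Nc2c(-c3ccc(Cl)cc3)nc3cnccn23)cc1` which differs from compound 2 by chloro in place of fluoro on an aromatic carbon, para to a large group (chloro in place of fluoro on an aromatic carbon). Within the data shown here, no measured pair shows this change. The expectation therefore starts from compound 2 at 56000 nM and allows only a small move toward a lower number, possibly none beyond the scatter. The expected move is a 1.4-fold lower number from compound 2 to compound 3 (0.15 log units; within the scatter) in this estimate. For compound 3 the estimated value is 40000 nM with an expected range from 15000 nM to 100000 nM in this assay.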

Compound 3, concentration lethal to 50% of the cells: 34000 nM
For compound 3 the middle estimate is 1.2-fold (0.07 log units) above the measured one, and the stated range covers the measured number.
By their numbers in this assay, from the lowest: compound 1; then compounds 3 and 2 (each within the scatter of the next).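

In this assay, among these compounds, the step of a 1.6-fold lower number from compound 2 to compound 3 (0.22 log units; within the scatter) gives the first comparison that changes a single place, 4-fluorophenyl to 4-chlorophenyl. On this aromatic carbon, para to a large group, chloro and fluoro therefore cannot be told apart by this read-out, and neither halogen can be ranked above the other. No measured information on the compounds bears on this result.

As far as these compounds go, whether this position responds to any group other than these two halogens remains open; an amine, a carboxylic acid or a nitrile at the same place would test that. Compound 1 differs from compound 2 and compound 3 in more than one place, so its value says nothing about this position.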